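Removing the side chain from compound 2

The source may report more compounds than this note shows. Statements on the series, on what has been measured and on what is new or still open speak of the compounds shown alone.

- compound 1 `CN1CCN(CCCn2c3c(c4ccccc42)C(=O)c2c[n+]([O-])c4ccccc4c2C3=O)CC1` with 170 nM
- compound 2 `O=C1c2c[n+]([O-])c3ccccc3c2C(=O)c2c1c1ccccc1n2Cc1cn(C[C@@H](O)CO)nn1` with 2030 nM

For the measured compounds named here, in a toxicity assay on HEK-293T cells (Homo sapiens) for cytotoxicity, read by MTT assay, with a stated time of 72 h (a higher number here means a weaker inhibitor, a lower number a stronger inhibitor), compound 2 holds the higher of the two numbers (2030 nM), and compound 1 is its only neighbour. Going by the values given here, the one measured step is a 12-fold higher number from compound 1 to compound 2 (1.08 log units; beyond the scatter) and it replaces 2-(4-methylpiperazin-1-yl)ethyl with 1-(2,3-dihydroxypropyl)-1H-1,2,3-triazol-4-yl on a saturated chain carbon bound to an aromatic nitrogen. Compound 3 `O=C1c2c[n+]([O-])c3ccccc3c2C(=O)c2[nH]c3ccccc3c21` has hydrogen in place of (1-(2,3-dihydroxypropyl)-1H-1,2,3-triazol-4-yl)methyl on an aromatic nitrogen. Among the compounds with values here, no measured compound lacks a side chain, so that step bears only indirectly, showing that side chains on the shared core can differ widely in this assay values. A moderate move towards a lower number is expected, ending between the two measured compounds. The expected move is a 3.4-fold lower number from compound 2 to compound 3 (0.53 log units; beyond the scatter) on this estimate. Compound 3 is therefore estimated at 600 nM (range 150 nM to 2000 nM).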

Compound 3, half-maximal inhibitory concentration: 890 nM
Compound 3: middle estimate off by 1.5-fold (0.17 log units), on the low side; the measured number falls inside the stated range.
By their numbers in this assay, from the lowest: compound 1; then compound 3; then compound 2.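

Hydrogen on the aromatic nitrogen gives this position a reference point in this assay: the change shows a 2.3-fold lower number from compound 2 to compound 3 (0.36 log units; beyond the scatter) when (1-(2,3-dihydroxypropyl)-1H-1,2,3-triazol-4-yl)methyl leaves, but a 5.2-fold higher number from compound 1 to compound 3 (0.72 log units; beyond the scatter) when 3-(4-methylpiperazin-1-yl)propyl leaves. Measured against hydrogen, the two side chains therefore move the number in opposite directions, so the large gap between them is not the result of one chain merely adding to the effect of the other. No evidence on why this happens is available.

Going by these compounds, it remains open whether the lower number of compound 1 depends on the terminal 4-methylpiperazine or on the propyl chain itself. A morpholine or a primary amine at the end of the same chain, or a plain methyl on the aromatic nitrogen, could separate these possibilities.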